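The source may report more compounds than this note shows. Statements on the series, on what has been measured and on what is new or still open speak of the compounds shown alone.

Of the compounds shown here, three have so far been measured in a physicochemical assay for lipophilicity; on this read-out higher numbers stand for higher lipophilicity and lower numbers for lower lipophilicity. Compound 1 `C=CC(C)OC(=O)/C=C(C)/C=C/CC(C)CCCC(C)(C)OC` gives 5.94, the smallest of the three numbers. Compound 3 `COC(CCC(C)C/C=C/C(C)=C/C(=O)OC(C)C)C(C)C` gives 5.95, a number that sits within the usual scatter of the value of compound 1, so these two cannot be told apart by this measurement. Going by the values given here, compound 2 `CCOC(=O)/C=C(C)/C=C/CC(C)CCCC(C)(C)SC` gives 6.36, and its distance from compound 1 lies beyond the scatter, so compound 2 is the one number that clearly stands higher. No two of the measured compounds differ in only one place, so no single step can be read off among them.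

Compound 4 `COC(C)(C)CCCC(C)C/C=C/C(C)=C/C(=O)CC(C)C` has not yet been measured in this assay. It differs from compound 1 in one place: isobutyl in place of (1-methylprop-2-en-1-yl)oxy on a carbonyl carbon. Cut one bond further out, the same change reads ((1-methylprop-2-en-1-yl)oxy)carbonyl to isobutylcarbonyl. Among the compounds with values here, since no comparable step between measured compounds exists, the expectation rests on the starting point and on the nature of the change alone. In this assay the change is expected to give a small step upward, a number 0.26 log units higher from compound 1 to compound 4 (within the scatter), of about the size of the scatter. Starting from the value compound 1 gives, 5.94, compound 4 is expected to reach 6.2, with a range from 5.8 to 6.6.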

Compound 4, partition coefficient: 6.02
The estimate for compound 4 lay 0.18 log units above the measured number, within the range that was stated.
By their numbers in this assay, from the lowest: compounds 1, 3 and 4 (each within the scatter of the next); then compound 2.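

In this assay, going by these compounds alone, this is the first step that can be read at this position, and putting isobutyl in place of (1-methylprop-2-en-1-yl)oxy on a carbonyl carbon gives a number 0.08 log units higher from compound 1 to compound 4 (within the scatter), so this measurement does not separate the two compounds. The change is not a trivial one on paper: the group that leaves has 5 heavy atoms, a double bond and a hydrogen-bond acceptor, while the isobutyl that enters has 4 heavy atoms and neither of the other two features, yet the two numbers still cannot be told apart. No other measurement bears on this result, so the closeness of the two numbers remains unexplained.

This single step cannot show whether the same swap would read the same way on the different cores of compound 2 or compound 3. It also leaves open how the number would respond if an amine, a carboxylic acid or a longer chain stood on this carbonyl carbon instead.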